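This account rests on a few compounds, and the source may have more. Where it says the series, first, only, none or still open, it means among the compounds named here.

Three compounds have been measured in an in vitro assay on BTI-TN-5B1-4 cells for inhibition of Amine oxidase [flavin-containing] A (Homo sapiens), read by fluorescence; on this read-out lower numbers stand for stronger inhibition and higher numbers for weaker inhibition:

compound 1, `O=C(Nc1ccccc1)c1cc2ccccc2oc1=O`, gives 13100 nM
compound 2, `O=C(Nc1ccc(F)cc1)c1cc2ccccc2oc1=O`, gives 13100 nM
compound 3, `O=C(Nc1ccccc1Cc1ccccc1)c1cc2ccc(OCc3ccccc3)cc2oc1=O`, gives 51900 nM

Compound 2 differs from compound 1 by one change, (fluoro in place of hydrogen on an aromatic carbon), and in this assay this step reads no change at the digits printed from compound 1 to compound 2 (within the scatter). Compound 3 stands highest of the three; the gap from compound 1 or compound 2 to compound 3 is beyond the scatter. The difference between the core of compound 3 and the core of compound 1 is not broken down here.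

Compound 4, `O=C(Nc1ccccc1Cc1ccccc1)c1cc2ccc(OCc3ccc(F)cc3)cc2oc1=O`, has not yet been measured. Going by the values given here, it differs from compound 3 by fluoro in place of hydrogen on an aromatic carbon, which is the same change as the one from compound 1 to compound 2, at a place described in the same words. The expectation for compound 4 in this assay therefore rests on that earlier step: because no change at the digits printed from compound 1 to compound 2 (within the scatter) showed no movement, the step from compound 3 to compound 4 is expected to read a 1.0-fold higher number from compound 3 to compound 4 (0.00 log units; within the scatter). Compound 4 is accordingly estimated at 52000 nM, with a range from 22000 nM to 125000 nM.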

Compound 4, half-maximal inhibitory concentration: 55800 nM
For compound 4 the middle estimate is 1.1-fold (0.03 log units) below the measured one; the measured number falls inside the stated range.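

In this assay the new step reads a 1.1-fold higher number from compound 3 to compound 4 (0.03 log units; within the scatter) and so shows no movement beyond the scatter, here with benzyloxy going to (4-fluorobenzyl)oxy on the core of compound 3. Going by these compounds alone, this rests on only two cores and a single kind of substitution, so it does not show that the change would stay as silent on other cores or at other places on these rings. Within these four compounds, fluoro in place of hydrogen carries from the core of compound 1 to the core of compound 3 with no difference between the two steps beyond the scatter: the same change on two cores in this assay, no change at the digits printed (within the scatter) from compound 1 to compound 2 and a 1.1-fold higher number (0.03 log units; within the scatter) from compound 3 to compound 4, 1.1-fold (0.03 log units) apart, within the scatter of two such steps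

The compounds shown leave open whether a different group at the same place, such as chloro, methoxy, a nitrile, an amine or a carboxylic acid, would move the number at all. Also open is which part of the difference between compound 3 and compound 1 accounts for the gap between them, as those two compounds differ in more than one place.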